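The source may report more compounds than this note shows. Statements on the series, on what has been measured and on what is new or still open speak of the compounds shown alone.

Measured so far in an ADME assay on Vero cells (Chlorocebus sabaeus) for cytotoxicity; on this read-out lower numbers stand for higher toxicity in this test and higher numbers for lower toxicity in this test: compound 1 `O[C@@H]1Cc2cc(Cl)ccc2N[C@H](c2cccs2)C1` with 164000 nM; compound 2 `O[C@@H]1Cc2cc(F)ccc2N[C@H](c2cccs2)C1` with 218000 nM; compound 3 `Cc1ccc([C@@H]2C[C@H](O)Cc3cc(Cl)ccc3N2)o1` with 300000 nM.

Compound 1 and compound 2 differ by fluoro in place of chloro on an aromatic carbon, and this change gave a 1.3-fold higher number from compound 1 to compound 2 (0.12 log units; within the scatter). Compound 3 differs from compound 1 by 5-methylfuran-2-yl in place of thiophen-2-yl on a saturated ring carbon, giving a 1.8-fold higher number from compound 1 to compound 3 (0.26 log units; within the scatter). Compound 4 `Cc1ccc([C@@H]2C[C@H](O)Cc3cc(F)ccc3N2)o1` has not yet been measured in this assay. It differs from compound 3 by fluoro in place of chloro on an aromatic carbon, the same change, at the same place, as that between compound 1 and compound 2. Because a 1.3-fold higher number from compound 1 to compound 2 (0.12 log units; within the scatter) stayed within the scatter, the expected step is correspondingly small, a 1.2-fold higher number from compound 3 to compound 4 (0.09 log units; within the scatter). Compound 4 is therefore estimated at 370000 nM in this assay, with the likely range expected between 180000 nM and 750000 nM.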

Compound 4, half-maximal cytotoxic concentration: 823000 nM
For compound 4 the middle estimate is 2.2-fold (0.35 log units) below the measured one; measured number outside the range, above it.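

In this assay, fluoro in place of chloro on an aromatic carbon gave a 2.7-fold higher number from compound 3 to compound 4 (0.44 log units; beyond the scatter), and this step does not differ measurably from the one on the other core: the same change on two cores in this assay, a 1.3-fold higher number (0.12 log units; within the scatter) from compound 1 to compound 2 and a 2.7-fold higher number (0.44 log units; beyond the scatter) from compound 3 to compound 4, 2.1-fold (0.31 log units) apart, within the scatter of two such steps. Likewise, 5-methylfuran-2-yl in place of thiophen-2-yl on a saturated ring carbon gave a 3.8-fold higher number from compound 2 to compound 4 (0.58 log units; beyond the scatter), again in line with the earlier step: the same change on two cores in this assay, a 1.8-fold higher number (0.26 log units; within the scatter) from compound 1 to compound 3 and a 3.8-fold higher number (0.58 log units; beyond the scatter) from compound 2 to compound 4, 2.1-fold (0.31 log units) apart, within the scatter of two such steps. Both changes thus carried from one core to the other within the scatter, but each comparison rests on just two steps and shows neither that the sizes would hold on further cores nor why they arise.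

The compounds shown leave open how a nitrile or a methoxy group would behave in place of the halogen. They also leave open what an amine in place of the hydroxyl group would do to this read-out.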